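Alkyne substituent change in an antiproliferative series

The source may hold more compounds than are shown below. What is called first, only, known or untested is meant among the compounds shown, and "the series" means these compounds.

compound 1 `Cc1ccc(C#Cc2cn(C/C=C\CN3C(=O)c4ccccc4C3=O)c(=O)[nH]c2=O)cc1`: > 100000 nM
compound 2 `CCCCCCCCC#Cc1cn(C/C=C\CN2C(=O)c3ccccc3C2=O)c(=O)[nH]c1=O`: 64000 nM

Compound 1 gives only a limit in a functional assay on MCF7 cells (Homo sapiens) for antiproliferative activity, read by MTT assay, with a stated time of 3 days (on this read-out higher numbers stand for weaker inhibition and lower numbers for stronger inhibition), > 100000 nM. Compound 2 gives 64000 nM in this assay, the only number shown here. Among the measured compounds shown here, the single measured step, an at least 1.5-fold lower number from compound 1 to compound 2 (0.19 log units; that floor lies within the scatter), is small, and the series sits close to the limit of > 100000 nM in this assay, at which 1 of the 2 values shown sits. Compound 3 `O=C1c2ccccc2C(=O)N1C/C=C\Cn1cc(C#Cc2ccc(Br)cc2)c(=O)[nH]c1=O` differs from compound 2 by 4-bromophenyl in place of octyl on a triple-bonded carbon. Compound 3 carries an aryl group as compound 1 does, and compound 1 gives only a limit. The expected step in this assay is a 1.6-fold higher number from compound 2 to compound 3 (0.19 log units; within the scatter), toward weaker inhibition. Compound 3 is estimated at 100000 nM, between 30000 nM and 300000 nM, with a real chance of only a limit.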

Compound 3, half-maximal inhibitory concentration: > 100000 nM
Compound 3: no number, only a limit (the forecaster's own chance of this, stated with the estimate: 50%); the middle value sits exactly at the limit.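

Compound 3 gives only a limit in this assay, so 4-bromophenyl on the triple-bonded carbon yields no number, and the series stays at the edge of the range: the limit of > 100000 nM in this assay, at which 2 of the 3 values shown sit.

The step of an at least 1.5-fold higher number from compound 2 to compound 3 (0.19 log units; that floor lies within the scatter) is only a floor, so it does not separate octyl from 4-bromophenyl. The other step, bromo in place of methyl on an aromatic carbon, cannot be read, since both of its ends are limits.

Still open, from the compounds shown here alone, is whether a shorter chain, a longer chain or a phenyl carrying an amine or a carboxylic acid on the triple-bonded carbon gives a number clearly inside the range of this assay.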